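A few compounds are considered here, and "the series" means these few. Any claim that something is new, unique, unknown or untested is made for them only; others in the source may bear on it.

Values in an ADME assay (liver, Mus musculus) for metabolic stability, using microsomes (a lower number here means that the compound disappears faster, a higher number that the compound lasts longer), are as follows.

- Compound 1 `CCc1nc2cc(Cl)ccn2c1C(=O)NCc1ccc(-c2ccc(Cl)cc2)cc1` gives > 1 h as a limit
- Compound 2 `CCc1nc2cc(Cl)ccn2c1C(=O)NCc1ccc(-c2ccc(C(=O)O)cc2)cc1` gives > 2 h as a limit
- Compound 3 `CCc1nc2cc(Cl)ccn2c1C(=O)NCc1ccc(N2CCCCC2)cc1` gives 0.0383 h as a true number

Among the measured compounds shown here, compound 3 holds the only true number here and sits far below both limits. Compound 4 `CCc1nc2cc(Cl)ccn2c1C(=O)NCc1ccc(N2CCCCCC2)cc1` carries azepan-1-yl in place of piperidin-1-yl on an aromatic carbon and is otherwise the same. For the measured compounds named here, two measured steps bear on this place: an at least 26-fold lower number from compound 1 to compound 3 (1.41 log units; beyond the scatter) and an at least 52-fold lower number from compound 2 to compound 3 (1.71 log units; beyond the scatter) are both large and beyond the scatter. Each replaces a whole substituted phenyl group, however, while here the ring only grows from six-membered to seven-membered. The expected result is a 1.3-fold lower number from compound 3 to compound 4 (0.11 log units; within the scatter) and nothing beyond the scatter. The estimate for compound 4 is 0.03 h with an expected range from 0.014 h to 0.07 h in this assay as well.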

Compound 4, half-life: 0.0317 h
For compound 4 the middle estimate is 1.1-fold (0.02 log units) below the measured one; measured number inside the range.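

In this assay, azepan-1-yl in place of piperidin-1-yl gives a 1.2-fold lower number from compound 3 to compound 4 (0.08 log units; within the scatter), so going from a six-membered to a seven-membered ring does not separate these two compounds. The large gap to the substituted phenyl groups holds for the new ring too, with an at least 63-fold lower number from compound 2 to compound 4 (1.79 log units; beyond the scatter) and an at least 31-fold lower number from compound 1 to compound 4 (1.49 log units; beyond the scatter), so it is not particular to piperidin-1-yl. Nothing measured here accounts for this gap. Still open, going by these compounds, is whether a smaller ring such as pyrrolidin-1-yl would give a similar number. The same goes for morpholin-4-yl, with its ring oxygen, or an open-chain diethylamino group.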